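The source may hold more compounds than are shown below. What is called first, only, known or untested is meant among the compounds shown, and "the series" means these compounds.

Of the compounds shown here, three from this series have been tested in a functional assay on IGROV-1 cells (Homo sapiens) for cytotoxicity, read by sulforhodamine B assay, with a stated time of 48 h; a higher number here means a weaker inhibitor of growth, a lower number a stronger inhibitor of growth. Compound 1 `ClCc1ccc(Cn2cnc3c(Cl)ncnc32)cc1` gives 3160 nM, compound 2 `Nc1nc(Cl)c2ncn(Cc3ccccc3CCl)c2n1` gives 6310 nM, and compound 3 `ClCc1ccccc1Cn1cnc2ncnc(Cl)c21` gives 4260 nM. Compound 2 shows the largest of the three numbers, yet compound 3 and compound 1 both fall within the usual scatter of it, so none of the three can be set apart. Compound 4 `ClCc1ccccc1Cn1cnc2c(Cl)nc(Cl)nc21` has not been measured. It differs from compound 2 in one place: chloro in place of amino on an aromatic carbon. Since compounds 1 and 3, which carry no amino group at that carbon, sit within the scatter of compound 2, the change is expected to give a step of a 1.3-fold lower number from compound 2 to compound 4 (0.10 log units; within the scatter), not beyond the scatter. Compound 4 is therefore estimated at 5000 nM, in a range from 1500 nM to 16000 nM.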

Compound 4, concentration for 50% growth inhibition: 1540 nM
For compound 4 the middle estimate is 3.2-fold (0.51 log units) above the measured one, and the stated range covers the measured number.
By their numbers in this assay, from the lowest: compound 4; then compounds 1, 3 and 2 (each within the scatter of the next).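

In this assay, within the data shown here, chloro in place of amino on this aromatic carbon, between two ring nitrogen atoms, gives a 4.1-fold lower number from compound 2 to compound 4 (0.61 log units; beyond the scatter) and is the first single change that can be read. It shows that growth inhibition responds to the group at this position, with chloro the stronger of the two groups compared. Nothing measured here explains the step.

On these data alone, how a bromo, methoxy or methylamino group on this carbon would compare remains open. As far as these compounds go, whether the step carries over to other cell lines also remains open.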